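The source may hold more compounds than are shown below. What is called first, only, known or untested is meant among the compounds shown, and "the series" means these compounds.

Compound 1 `COc1ccc(OCCCOc2ccc3c(O)c([N+](=O)[O-])c(=O)oc3c2)cc1` belongs to a small set of relatives that share one core and differ only in the aromatic group at the far end of the three-carbon chain. In a functional assay on ileum (Cavia porcellus) for antagonist activity (on this read-out lower numbers stand for stronger inhibition and higher numbers for weaker inhibition), compound 1 gives only a limit, > 4000 nM. Compound 2 `N#Cc1ccc(OCCCOc2ccc3c(O)c([N+](=O)[O-])c(=O)oc3c2)cc1` likewise gives only a limit in this assay, > 10000 nM. Compound 3 `Cc1ccc(OCCCOc2ccc3c(O)c([N+](=O)[O-])c(=O)oc3c2)cc1` gives 4500 nM in this assay. Among these three lie a step that the two limits leave unreadable from compound 1 to compound 2, a step that the limit leaves unreadable from compound 1 to compound 3 and an at least 2.2-fold lower number from compound 2 to compound 3 (0.34 log units; beyond the scatter). Compound 4 `Cc1ccc(OCCCOc2ccc3c(O)c([N+](=O)[O-])c(=O)oc3c2)c([N+](=O)[O-])c1` differs from compound 1 in one place: 4-methyl-2-nitrophenyl in place of 4-methoxyphenyl on an oxygen on a saturated carbon. Because compound 3, which carries the same methyl, gives 4500 nM, compound 4 is expected to show a step that the limit leaves unreadable from compound 1 to compound 4. Compound 4 is therefore estimated at 5000 nM, between 2000 nM and 15000 nM.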

Compound 4, half-maximal inhibitory concentration: > 10000 nM
Compound 4 ended at the assay's limit; the forecaster's own chance of this, stated with the estimate: 40%; at least 2.0-fold (0.30 log units) between middle value and limit.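

In this assay, among these compounds, placing nitro in place of hydrogen on an aromatic carbon gives an at least 2.2-fold higher number from compound 3 to compound 4 (0.34 log units; beyond the scatter), so adding a group to the methyl-bearing ring weakens inhibition, whereas the earlier compounds only swapped one group for another. As far as these compounds go, compound 4 gives > 10000 nM, which is a limit of the assay, so the true size of this step remains unknown. The steps linking compound 4 to compound 1 and compound 2 cannot be read.

From the compounds shown here alone, whether nitro would have the same effect without the methyl remains open. So does whether an amine or a carboxylic acid on that ring, or a longer chain, would restore inhibition.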